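Swapping the Tetrazole Arm for an Aminothiazole

This account rests on a few compounds, and the source may have more. Where it says the series, first, only, none or still open, it means among the compounds named here.

Compound 1 `CC(C)C(c1ncc[nH]1)c1ccc(-c2ccc3cccc(F)c3c2)[nH]c1=O`: in an ADME assay on microsomes from liver (Rattus norvegicus) for metabolic stability (a higher number here means that the compound lasts longer, a lower number that the compound disappears faster), compound 1 gives < 0.0667 h, which is a limit of the assay and not a number.
Compound 2 `CC(C)C(c1noc(=O)[nH]1)c1ccc(-c2ccc3cccc(F)c3c2)[nH]c1=O`: in this assay compound 2 gives > 3 h, again a limit of the assay.
Compound 3 `CC(C)C(Cc1nnn[nH]1)c1ccc(-c2ccc3cccc(F)c3c2)[nH]c1=O`: in this assay compound 3 gives 2.08 h.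

Among the three measured compounds, compound 3 carries the only value that is a number; the others sit at the limits the limit of < 0.0667 h in this assay, at which 1 of the 3 values shown sits, and (the limit of > 3 h in this assay, at which 1 of the 3 values shown sits). Compound 4 `CC(C)C(c1cnc(N)s1)c1ccc(-c2ccc3cccc(F)c3c2)[nH]c1=O` differs from compound 3 in one place: 2-amino-1,3-thiazol-5-yl in place of (1H-tetrazol-5-yl)methyl on a saturated chain carbon bound to an aromatic carbon and a saturated chain carbon.

Within the data shown here, two measured steps bear on this change. Leaving the imidazole of compound 1 gave an at least 44-fold higher number from compound 1 to compound 2 (1.65 log units; beyond the scatter) and an at least 31-fold higher number from compound 1 to compound 3 (1.49 log units; beyond the scatter), both large. Between the two rings that replaced it, an at least 1.4-fold lower number from compound 2 to compound 3 (0.15 log units; that floor lies within the scatter) shows no clear difference. Compound 4 returns to a five-membered aromatic ring with 2 hetero atoms, attached directly to the saturated chain carbon as in compound 1, rather than through a methylene as in compound 3. A large downward step is therefore expected, a 10-fold lower number from compound 3 to compound 4 (1.02 log units; beyond the scatter), in this assay. Compound 4 is estimated at 0.2 h, with a likely range from 0.05 h to 0.8 h, and a real chance that only a limit is reported.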

Compound 4, half-life: 0.0983 h
For compound 4 the middle estimate is 2.0-fold (0.31 log units) above the measured one; the measured number falls inside the stated range.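

In this assay, the 2-amino-1,3-thiazol-5-yl group brings a large loss, with a 21-fold lower number from compound 3 to compound 4 (1.33 log units; beyond the scatter) and an at least 30-fold lower number from compound 2 to compound 4 (1.48 log units; beyond the scatter), so the short-lived end of this small set is no longer held by the imidazole of compound 1 alone. The two compounds with a five-membered aromatic ring with 2 hetero atoms, compound 1 and compound 4, now stand low, although their rings differ in their atoms and compound 4 carries an amino group; none of the four compounds goes against this pattern. Set against the imidazole, the step is an at least 1.4-fold higher number from compound 1 to compound 4 (0.16 log units; that floor lies within the scatter), so no clear difference can be claimed, and compound 1 gives only a limit of the assay and not a number: the limit of < 0.0667 h in this assay, at which 1 of the 4 values shown sits.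

Going by these compounds, compound 4 differs from compound 3 in both the ring and the methylene, so the share of each in the loss stays open. A (2-amino-1,3-thiazol-5-yl)methyl group, or a thiazole without the amine, would separate the methylene and the amino group from the ring itself.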